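This account rests on a few compounds, and the source may have more. Where it says the series, first, only, none or still open, it means among the compounds named here.

Working notes on the series in a functional assay on A-375 cells (Homo sapiens) for cytotoxicity, read by MTT assay; on this read-out lower numbers stand for stronger inhibition and higher numbers for weaker inhibition.

Of the compounds shown here, three have numbers so far. Compound 1 `O=S(=O)(NCCCNc1nccc(-c2c(-c3cccc(F)c3)nc3sccn23)n1)c1ccc(C(F)(F)F)cc1` gives 4090 nM in this assay. Compound 2 `O=S(=O)(NCCNc1nccc(-c2c(-c3cccc(F)c3)nc3sccn23)n1)c1ccc(C(F)(F)F)cc1` gives 7440 nM in this assay. Compound 3 `O=C(NCCNc1nccc(-c2c(-c3cccc(F)c3)nc3sccn23)n1)c1ccc(C(F)(F)F)cc1` gives 8710 nM in this assay, the highest of the three numbers; its gap to compound 2 lies within the usual scatter, while its gap to compound 1 lies beyond it. Among the compounds with values here, no pair among the three differs in a single place, so no step between measured compounds can be read off, and nothing in the set isolates the effect of a single group.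

The next compound, compound 4 `Cc1ccc(C(=O)NCCNc2nccc(-c3c(-c4cccc(F)c4)nc4sccn34)n2)cc1`, differs from compound 3 by methyl in place of trifluoromethyl on an aromatic carbon, para to a large group. Within the data shown here, no measured pair carries this change, so its size is not known from the series. The expectation is that the step of a 1.1-fold higher number from compound 3 to compound 4 (0.06 log units; within the scatter) from compound 3 to compound 4 in this assay stays within the scatter, with no clear direction. Compound 4 is therefore estimated at 10000 nM in this assay, with a range from 4000 nM to 25000 nM.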

Compound 4, half-maximal inhibitory concentration: 5880 nM
The estimate for compound 4 lay 1.7-fold (0.23 log units) above the measured number, and the stated range covers the measured number.
By their numbers in this assay, from the lowest: compounds 1, 4, 2 and 3 (each within the scatter of the next, the first and the last beyond it).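

In this assay, within the data shown here, compound 3 and compound 4 form the first pair that differs in one place, so the size of a single change can now be read (a 1.5-fold lower number from compound 3 to compound 4 (0.17 log units; within the scatter)). Methyl in place of trifluoromethyl on an aromatic carbon, para to a large group, leaves the two compounds indistinguishable, and in this amide pair the trifluoromethyl group is not required for a number of this size. No measurement here bears on why the two groups give matching numbers.

Going by these compounds, what remains open is whether this position responds at all, since a single change that stays within the scatter cannot separate a position that tolerates many groups from two groups that merely happen to match, and a methoxy group, a carboxylic acid or an amine in the same place would test this. On these data alone, it is also open whether the same swap of 4-(trifluoromethyl)phenyl to 4-methylphenyl would behave in the same way in a sulfonamide such as compound 2 or compound 1.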